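A few compounds are considered here, and "the series" means these few. Any claim that something is new, unique, unknown or untested is made for them only; others in the source may bear on it.

Compound 1 `COCc1ccc(-c2ccc3nnc(C(N)=O)c(N[C@@H](C)c4nn(C)cc4C)c3c2)cn1` gives 44 nM in an assay on HT-29 cells for inhibition of Serine-protein kinase ATM (Homo sapiens), read by fluorescence, with a stated time of 1 h (a lower number here means a stronger inhibitor, a higher number a weaker inhibitor), the lower of the two numbers in hand. Compound 2 `CNC(=O)c1nnc2ccc(-c3ccc(COC)nc3)cc2c1N[C@@H](C)C1CCOCC1` gives 330 nM in this assay; the two compounds differ in more than one place, so only their two values stand side by side. Compound 3 `Cc1cn(C)nc1[C@H](C)Nc1c(C(N)=O)nnc2ccc(-c3ccc(OCCCN(C)C)nc3)cc12` carries 3-(dimethylamino)propoxy in place of methoxymethyl on an aromatic carbon, a 3-(dimethylamino)propoxy in place of methoxymethyl on an aromatic carbon. For the measured compounds named here, no measured pair isolates this change, so the step from compound 1 is expected to stay within the scatter, in no settled direction, at a 1.0-fold higher number from compound 1 to compound 3 (0.01 log units; within the scatter) as the estimated size. Compound 3 is thus expected to give about 45 nM, ranging from 15 nM to 130 nM.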

Compound 3, half-maximal inhibitory concentration: 0.9 nM
Beside the measured number, compound 3's estimate is 50-fold (1.70 log units) above it; the measured number lies below the stated range.
By their numbers in this assay, from the lowest: compound 3; then compound 1; then compound 2.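

With the rest of the structure unchanged, placing 3-(dimethylamino)propoxy in place of methoxymethyl on the aromatic carbon next to the ring nitrogen gives a 49-fold lower number from compound 1 to compound 3 (1.69 log units; beyond the scatter) in this assay. For the compounds shown here, compound 1 and compound 2 both carry methoxymethyl there, so only this step shows that this assay responds strongly to the group at this position. Nothing in hand accounts for the size of this step.

Still open, from the compounds shown here alone, is whether the step depends on the terminal dimethylamine or on the chain, which a propoxy chain without an amine, a longer chain or a morpholine would help separate. Going by these compounds, it is also open whether the same replacement would have a similar effect on the core of compound 2.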